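A few compounds are considered here, and "the series" means these few. Any claim that something is new, unique, unknown or untested is made for them only; others in the source may bear on it.

Measured compounds:
- compound 1, `O=C1c2c(ccc(O)c2O)CN1Cc1cccc(F)c1`, in an ADME assay on HOS cells (Homo sapiens) for cytotoxicity (a higher number here means a weaker inhibitor, a lower number a stronger inhibitor), gives 8600 nM
- compound 2, `O=C1c2c(ccc(O)c2O)CN1Cc1cccc(Cl)c1`, in this assay gives 9020 nM
- compound 3, `O=C1c2ccc(O)c(O)c2C(=O)N1Cc1ccc(F)c(Cl)c1`, in this assay gives 9540 nM

Compound 1 and compound 2 share a core and differ only by chloro in place of fluoro on an aromatic carbon. That step produced a 1.0-fold higher number from compound 1 to compound 2 (0.02 log units; within the scatter). Compound 3 has a different core; how the two cores differ is not broken down here. Compound 4, `O=C1c2ccc(O)c(O)c2C(=O)N1Cc1ccc(Cl)c(Cl)c1`, has not yet been measured; it differs from compound 3 by chloro in place of fluoro on an aromatic carbon. Within the data shown here, this is the same kind of change as the one from compound 1 to compound 2, though its surroundings differ: in compound 4 the place is ortho to a chloro group and para to a large group, whereas in compound 2 it is meta to a large group. Since the earlier step stayed within the scatter, compound 4 is expected to stand near compound 3, with an estimated step of a 1.0-fold higher number from compound 3 to compound 4 (0.01 log units; within the scatter). For compound 4 the estimated value in this assay is 9800 nM, expected to fall between 5000 nM and 19000 nM.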

Compound 4, half-maximal inhibitory concentration: 4430 nM
Compound 4: the middle estimate sits 2.2-fold (0.34 log units) above what was measured; measured number outside the range, below it.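

In this assay, chloro in place of fluoro gives a 2.2-fold lower number from compound 3 to compound 4 (0.33 log units; beyond the scatter), a modest step on the core of compound 3. Set beside the same change on the other core, this step cannot be told apart from the earlier one: the same change on two cores in this assay, a 1.0-fold higher number (0.02 log units; within the scatter) from compound 1 to compound 2 and a 2.2-fold lower number (0.33 log units; beyond the scatter) from compound 3 to compound 4, 2.3-fold (0.35 log units) apart, within the scatter of two such steps. Among these compounds, this gives no sign that the core alters the effect of the change, but it does not show that the effect carries over unchanged either, since it rests on only two pairs and the place in compound 4 is ortho to a chloro group and para to a large group.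

Going by these compounds, what a methoxy group, a nitrile or an amine would do at this place remains open. So does whether the step would repeat on further cores.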